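The source may report more compounds than this note shows. Statements on the series, on what has been measured and on what is new or still open speak of the compounds shown alone.

Of the compounds shown here, three sharing one core have been measured in an assay on isolated protein for binding affinity to histamine H2 receptor (Homo sapiens); a lower number here means a stronger inhibitor, a higher number a weaker inhibitor. Compound 1 `CCCCCC(=O)c1ccc(OCCCN2CCN(C(=O)OC)CC2)cc1` gives 12000 nM in this assay. Compound 2 `CCCCCC(=O)c1ccc(OCCCN2CCN(S(=O)(=O)c3ccc(C#N)cc3)CC2)cc1` gives 12300 nM, and compound 3 `CCCCCC(=O)c1ccc(OCCCN2CCN(C(=O)C3CCC3)CC2)cc1` gives 10200 nM. Compound 3 has the lowest of the three numbers, but its distance to each of the others is small: the step of a 1.2-fold lower number from compound 1 to compound 3 (0.07 log units; within the scatter) and the step of a 1.2-fold lower number from compound 2 to compound 3 (0.08 log units; within the scatter) both stay within the scatter, so the three compounds cannot be told apart on these numbers.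

Compound 4 `CCCCCC(=O)c1ccc(OCCCN2CCN(C(=O)C(C)(C)O)CC2)cc1` differs from compound 3 in one place: 1-hydroxy-1-methylethyl in place of cyclobutyl on a carbonyl carbon, the carbonyl carbon whose other neighbour is the amide-type nitrogen in the ring. Going by the values given here, the one measured step at the same position, a 1.2-fold lower number from compound 1 to compound 3 (0.07 log units; within the scatter), changed the number only within the scatter, and the exchange of the whole group on the ring nitrogen, a 1.0-fold higher number from compound 1 to compound 2 (0.01 log units; within the scatter), did the same. Compound 4 is therefore expected to show no step beyond the scatter, an estimated 1.0-fold lower number from compound 3 to compound 4 (0.01 log units; within the scatter), giving an expected value of 10000 nM with a range from 4500 nM to 25000 nM.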

Compound 4, inhibition constant: 24500 nM
The estimate for compound 4 lay 2.5-fold (0.39 log units) below the measured number; the measured number falls inside the stated range.
By their numbers in this assay, from the lowest: compounds 3, 1, 2 and 4 (each within the scatter of the next, the first and the last beyond it).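

Unlike the steps among compounds 1, 2 and 3, changes on this carbonyl carbon now pass the scatter in this assay: 1-hydroxy-1-methylethyl in place of cyclobutyl gives a 2.4-fold higher number from compound 3 to compound 4 (0.38 log units; beyond the scatter) and 1-hydroxy-1-methylethyl in place of methoxy gives a 2.0-fold higher number from compound 1 to compound 4 (0.31 log units; beyond the scatter), both modest in size. The exchange of the whole group on the ring nitrogen gives a 2.0-fold higher number from compound 2 to compound 4 (0.30 log units; within the scatter), so compound 4 cannot be told apart from compound 2. No measurement at hand explains these steps.

Going by these compounds, it remains open whether the hydroxyl or the loss of the ring matters more: a tert-butyl group on the same carbonyl carbon, or a cyclobutyl ring carrying a hydroxyl, would separate the two. On these data alone, how an amine or a carboxylic acid at this place would read in this assay is also open.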